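The compounds below may be only part of what the source reports. "The series", "measured", "known", "first", "only" and "open" are said of these compounds alone.

Compound 1 `C=C(C)[C@@H]1C[C@@H](CC2(CC=C(C)C)C(=O)C(C(CC(=O)O)c3ccccc3)=C3O[C@H](C)[C@@H](C)C(=O)C3=C2O)C1(C)C`: in a functional assay on cells for cytotoxicity (on this read-out higher numbers stand for weaker inhibition and lower numbers for stronger inhibition), compound 1 gives > 20 ug/mL, which is a limit of the assay and not a number.
Compound 2 `C=C(C)[C@@H]1C[C@@H](CC2(CC=C(C)C)C(=O)C(C(CC(=O)O)c3ccccc3)=C3O[C@@H](C)[C@@H](C)C(=O)C3=C2O)C1(C)C`: in this assay compound 2 gives > 20 ug/mL, again only a limit.
Compound 3 `C=C(C)[C@@H]1C[C@@H](CC2(CC=C(C)C)C(=O)C3=C(O)[C@@H](C)[C@@H](C)OC3=C(C(CC(=O)O)c3ccccc3)C2=O)C1(C)C`: in this assay compound 3 gives > 20 ug/mL, once more a limit.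

Compound 3 therefore stands where every value shown stands, at the edge of what the assay reports, as the limit of > 20 ug/mL in this assay, at which 3 of the 3 values shown sit, makes plain. Compound 4 `C=C(C)[C@@H]1C[C@@H](CC2(CC=C(C)C)C(=O)C3=C(O)[C@@H](C)[C@H](C)OC3=C(C(CC(=O)O)c3ccccc3)C2=O)C1(C)C` has not yet been measured. It differs from compound 3 only in configuration: the two compounds have the same atoms and bonds; at least one stereo element is drawn with a configuration in one of them and without one in the other: 1 of 6 stereo elements differ; a stereocentre at a saturated ring carbon is drawn R in compound 3 and S in compound 4. Going by the values given here, the one measured step of the same kind, a step that the two limits leave unreadable from compound 1 to compound 2, concerns a comparable single stereocentre, but its size cannot be read because the limit of > 20 ug/mL in this assay, at which 3 of the 3 values shown sit, places both of its compounds at the limit, and the fact that one of compounds 1 and 2 is drawn with a defined configuration and the other without, at the place where they differ describes the drawn difference between them. Among the compounds with values here, no measured step thus shows that swapping one ring stereocentre moves this read-out at all. Compound 4 is consequently expected to sit near 25 ug/mL, within a range from 10 ug/mL to 60 ug/mL, and most likely to be reported as a limit again. The expected step that the limit leaves unreadable from compound 3 to compound 4 is accordingly estimated to lie within the scatter.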

Compound 4, half-maximal inhibitory concentration: > 20 ug/mL
Compound 4: no number, only a limit; the forecaster's own chance of this, stated with the estimate: 75%; the middle value lies beyond the limit too.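

In this assay compound 4 gives > 20 ug/mL, again a limit of the assay and not a number. No size can be read for the step between compound 3 and compound 4. The compounds shown leave open whether the configuration at a saturated ring carbon changes this read-out at all.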